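Working notes: from compound 2 to compound 3

This account rests on a few compounds, and the source may have more. Where it says the series, first, only, none or still open, it means among the compounds named here.

In a functional assay on DLA cells (Mus musculus) for cytotoxicity, read by LDH release, with a stated time of 48 h (on this read-out higher numbers stand for weaker inhibition and lower numbers for stronger inhibition), compound 1 (`COc1ccc(-c2csc(NC(=O)COc3ccc(C(=O)c4ccccc4)cc3C)n2)cc1`) gives 26200 nM, and compound 2 (`COc1ccc(-c2csc(NC(=O)COc3ccc(C(=O)c4ccc(F)cc4)cc3C)n2)cc1`) gives 5500 nM. Compound 2 thus holds the lower of the two numbers, which makes it the stronger inhibitor of this pair. Going by the values given here, the only measured step is a 4.8-fold lower number from compound 1 to compound 2 (0.68 log units; beyond the scatter), with fluoro in place of hydrogen on an aromatic carbon.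

Compound 3 (`COc1ccc(-c2csc(NC(=O)COc3ccc(C(=O)c4cccc(Br)c4)cc3C)n2)cc1`) has not yet been measured. It differs from compound 2 by 3-bromophenyl in place of 4-fluorophenyl on a carbonyl carbon.

The measured step bears on this change only in part. Among the compounds with values here, it shows that one halogen can shift the number modestly, but no bromo compound has been measured, and the data do not separate the choice of halogen from where it sits. A step larger than the measured one is therefore not expected, and compound 2 offers only a slight lean toward a higher number. The step expected in this assay is a 1.5-fold higher number from compound 2 to compound 3 (0.16 log units; within the scatter). For compound 3 the estimated value is 8000 nM, with an expected range from 2500 nM to 26000 nM.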

Compound 3, half-maximal inhibitory concentration: 37100 nM
Compound 3: middle estimate off by 4.6-fold (0.67 log units), on the low side; the measured number lies above the stated range.
By their numbers in this assay, from the lowest: compound 2; then compounds 1 and 3 (each within the scatter of the next).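

In this assay the step of a 6.7-fold higher number from compound 2 to compound 3 (0.83 log units; beyond the scatter) shows that the lower number of compound 2 does not carry over to every halogen-bearing aryl group on the carbonyl carbon: 3-bromophenyl in place of 4-fluorophenyl gives up the gain seen with fluoro. With bromo in place of hydrogen, the step of a 1.4-fold higher number from compound 1 to compound 3 (0.15 log units; within the scatter) leaves compound 3 and compound 1 indistinguishable on this read-out, so a halogen at this part of the molecule does not by itself lower the number, and of the three aryl groups compared only the 4-fluorophenyl of compound 2 stands apart. Nothing on hand gives a reason for either step.

Halogen and its place on the aryl group change together between compound 2 and compound 3, so it stays open whether the identity of the halogen, its place, or both carry the step. Also open, going by these compounds, is how a chloro group, a methoxy group or an amine on this aryl group would move the number, and whether the lower number of compound 2 is particular to fluoro.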